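A few compounds are considered here, and "the series" means these few. Any claim that something is new, unique, unknown or untested is made for them only; others in the source may bear on it.

Measured so far:
Compound 1, `CCOC(=O)c1cccc(-c2ccc(OCC)nc2)c1`: 130000 nM
Compound 2, `CCNS(=O)(=O)c1cccc(-c2ccc(OCC)cc2)c1`: 200000 nM

Both compounds were tested in an assay on COS-7 cells for inhibition of patatin-like phospholipase domain-containing protein 2 (Mus musculus); a higher number here means a weaker inhibitor, a lower number a stronger inhibitor. Compound 1 gives 130000 nM, and compound 2 gives 200000 nM. Compound 2 shows the larger of the two numbers, but the gap to compound 1 lies within the scatter of repeated measurements, so the two compounds cannot be told apart on these data.

Compound 3, `CCCCOC(=O)c1cccc(-c2ccc(OCC)cc2)c1`, has not yet been measured. It differs from compound 2 in one place: butoxycarbonyl in place of ethylsulfamoyl on an aromatic carbon. Among the compounds with values here, no pair of measured compounds shows this particular change, so there is no measured step to lean on. What is known is that compound 1, an ester, and compound 2, a sulfonamide, sit close together, which gives no sign that swapping one group for the other moves the number far.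

In this assay compound 3 is therefore expected to stay in the same weak region, with an estimated value of 120000 nM, within a range from 30000 nM to 400000 nM. The expected step from compound 2 to compound 3 is a 1.7-fold lower number from compound 2 to compound 3 (0.22 log units; within the scatter), which would not go beyond the scatter.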

Compound 3, half-maximal inhibitory concentration: 100000 nM
Estimate against measurement, compound 3: 1.2-fold (0.08 log units) above, within the range that was stated.
By their numbers in this assay, from the lowest: compounds 3, 1 and 2 (each within the scatter of the next).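

In this assay, butoxycarbonyl in place of ethylsulfamoyl on this aromatic carbon gives a 2.0-fold lower number from compound 2 to compound 3 (0.30 log units; within the scatter), which is within the scatter of repeated measurements. Within the data shown here, this is the first measured exchange at this position, and it shows that the sulfur-containing group with its hydrogen-bond donor can give way to a longer ester chain with no hydrogen-bond donor, without a difference the assay can resolve. No measurement of any property of these groups is available that could explain this result.

The compounds shown leave open whether a carboxylic acid or an amine on this aromatic carbon would move the number out of this weak region. They also leave open what a longer chain on the ester would do.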